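The source may report more compounds than this note shows. Statements on the series, on what has been measured and on what is new or still open speak of the compounds shown alone.

In a functional assay on DU-145 cells (Homo sapiens) for inhibition, read by trypan blue exclusion, with a stated time of 96 h (on this read-out higher numbers stand for weaker inhibition of growth and lower numbers for stronger inhibition of growth), compound 1 (`O=C(/C(=C\c1c[nH]c2ccc(Cl)cc12)SCc1ccc(F)cc1)c1ccc(Br)cc1`) gives 1000 nM. Compound 2 (`Cc1ccc(S/C(=C/c2c[nH]c3ccc(Cl)cc23)C(=O)c2ccc(Br)cc2)cc1`) gives 1000 nM and compound 3 (`O=C(O)c1ccc(C(=O)/C(=C\c2ccc(Cl)c([N+](=O)[O-])c2)SCc2ccc(F)cc2)cc1`) gives 1000 nM, so compound 1 stands level with both of them. Compound 4 (`CN(C)c1ccc(/C=C(/SCc2ccc(F)cc2)C(=O)c2ccc(Br)cc2)cc1`) has not yet been measured. It differs from compound 1 in one place: 4-(dimethylamino)phenyl in place of 5-chloro-1H-indol-3-yl on a double-bonded chain carbon bound to a double-bonded chain carbon. The new group, 4-(dimethylamino)phenyl, replaces 5-chloro-1H-indol-3-yl on a double-bonded chain carbon bound to a double-bonded chain carbon, and the 4-fluorobenzyl on the sulfur stays.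

For the measured compounds named here, only one measured step is available, no change at the digits printed from compound 1 to compound 2 (within the scatter), and it concerns the group on the sulfur, so it bears on this change only indirectly. It shows that this assay did not separate those two compounds. Closer to the point, although it differs from compound 1 elsewhere too, compound 3 also lacks the 5-chloro-1H-indol-3-yl group, and compound 3 still gives 1000 nM. Going by the values given here, no measured pair isolates this exchange, so the evidence is thin. The expected size of no change at the digits printed from compound 1 to compound 4 (within the scatter) is nothing beyond the scatter, in neither direction. For compound 4 the estimated value is 1000 nM, with an expected range of 350 nM to 3000 nM.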

Compound 4, concentration for 50% growth inhibition: 50000 nM
Beside the measured number, compound 4's estimate is 50-fold (1.70 log units) below it; the measured number lies above the stated range.
By their numbers in this assay, from the lowest: compounds 1, 2 and 3 (each within the scatter of the next); then compound 4.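

In this assay the step of a 50-fold higher number from compound 1 to compound 4 (1.70 log units; beyond the scatter) marks this place, on a double-bonded chain carbon bound to a double-bonded chain carbon, as one where a single exchange separates two compounds beyond the scatter, whereas the step on the sulfur, no change at the digits printed from compound 1 to compound 2 (within the scatter), separated nothing. The higher number stands for weaker inhibition of growth, so in this pair, with the 4-fluorobenzyl on the sulfur unchanged, compound 1 with 5-chloro-1H-indol-3-yl is the stronger of the two and compound 4 with 4-(dimethylamino)phenyl the weaker. No measurement is at hand that would account for the size of this step.

The exchange alters several features at once, including the five-membered aromatic ring, the chlorine, the hydrogen-bond donor and the dimethylamino group, so this one pair cannot tell which of them matters. On these data alone, an unsubstituted 1H-indol-3-yl group, a 5-chlorophenyl-type ring without the five-membered ring, or a phenyl group bearing a primary amine in place of the dimethylamino group at this same place would divide the step into smaller parts, and whether the 4-methylphenyl on the sulfur would respond to the same exchange in the same way also remains open.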